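Para substituent exchange on the pendant phenyl ring

The compounds below may be only part of what the source reports. "The series", "measured", "known", "first", "only" and "open" are said of these compounds alone.

Of the compounds shown here, two carry numbers so far. Compound 1 `CCCS(=O)(=O)Nc1ccc(F)c(C(=O)c2n[nH]c3ncc(-c4ccccc4C)cc23)c1F` gives 7% in an assay for binding affinity to dual specificity mitogen-activated protein kinase kinase 4 (Homo sapiens), read by KINOMEscan, tested at 100 nM; on this read-out higher numbers stand for a weaker effect at the one concentration tested and lower numbers for a stronger effect. Compound 2 `CCCS(=O)(=O)Nc1ccc(F)c(C(=O)c2n[nH]c3ncc(-c4ccc(N)cc4)cc23)c1F` gives 0.1% in this assay; on the two numbers shown it stands lowest, with compound 1 nearest, and the step of a number 6.9 percentage points lower from compound 1 to compound 2 (within the scatter) lies within the scatter. Compound 3 `CCCS(=O)(=O)Nc1ccc(F)c(C(=O)c2n[nH]c3ncc(-c4ccc(S(=O)(=O)NC(C)=O)cc4)cc23)c1F` differs from compound 2 in one place: acetylsulfamoyl in place of amino on an aromatic carbon. Among the compounds with values here, no measured step bears directly on this exchange; the one step known, a number 6.9 percentage points lower from compound 1 to compound 2 (within the scatter), swaps a whole aryl substituent and stays within the scatter. Both measured numbers are low, so compound 3 is expected to remain low as well, with the step of a number 2.9 percentage points higher from compound 2 to compound 3 (within the scatter) estimated to stay within the scatter. For compound 3 in this assay the estimate is 3%, with a range from 0% to 15%.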

Compound 3, a percentage reported as activity, at one concentration (the size of the read-out at that concentration, not a potency): 0.35%
The estimate for compound 3 lay 2.7 percentage points above the measured number, and the stated range covers the measured number.
By their numbers in this assay, from the lowest: compounds 2, 3 and 1 (each within the scatter of the next).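

Exchanging amino for acetylsulfamoyl on the aromatic carbon para to a large group gives a number 0.3 percentage points higher from compound 2 to compound 3 (within the scatter) in this assay. This position therefore accepts a group of 7 heavy atoms in place of 1 heavy atom without a change beyond the scatter, which the earlier step, a swap of the whole aryl substituent, could not show for this position alone. No available evidence bears on the reason for this outcome.

Going by these compounds, whether a carboxylic acid, a tertiary amine or a longer acyl chain in place of the acetyl group would also stay within the scatter remains open. On these data alone, with both numbers close to zero and taken at one concentration, any difference in potency between compound 2 and compound 3 also remains open.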